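Vinyl for Methyl at the End of the Chain

The source may hold more compounds than are shown below. What is called first, only, known or untested is meant among the compounds shown, and "the series" means these compounds.

Measured compounds:
- compound 1, `CCCCCCCC(=O)Nc1nnc(S[C@@H]2O[C@H](CO)[C@H](O)[C@H](O)[C@H]2O)s1`: 56000 nM
- compound 2, `CCCCCCCCCC(=O)Nc1nnc(S[C@@H]2O[C@H](COC(C)=O)[C@H](OC(C)=O)[C@H](OC(C)=O)[C@H]2OC(C)=O)s1`: "not active" (no number reported)
- compound 3, `CCCCCCCC/C=C\CCCCCCCC(=O)Nc1nnc(S[C@@H]2O[C@H](CO)[C@H](O)[C@H](O)[C@H]2O)s1`: "not active" (no number reported)

In a functional assay on SK-OV-3 cells (Homo sapiens) for cytotoxicity, read by MTT assay, with a stated time of 24 h (a higher number here means a weaker inhibitor, a lower number a stronger inhibitor), compound 1 gives 56000 nM. In this assay compound 2 is recorded as "not active" (no number reported), and compound 3 as "not active" (no number reported). For the measured compounds named here, compound 2 therefore stands without a number; of the three, only compound 1 has a value, and no pair of them differs in just one place. Compound 4, `C=CCCCCCCCCC(=O)Nc1nnc(S[C@@H]2O[C@H](COC(C)=O)[C@H](OC(C)=O)[C@H](OC(C)=O)[C@H]2OC(C)=O)s1`, is not yet measured. It differs from compound 2 in one place: vinyl in place of methyl on a saturated chain carbon, eight bonds along the chain from a carbonyl carbon. Going by the values given here, no measured pair shows this kind of change, so there is nothing to suggest a shift beyond the scatter in either direction. In this assay compound 4 is expected to remain weak, with an estimated value of 100000 nM, likely between 40000 nM and 300000 nM, and it may well be reported as not active.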

Compound 4, half-maximal inhibitory concentration: "not active" (no number reported)
The entry for compound 4 holds no number; no gap can be computed for the estimate.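

In this assay compound 2 and compound 4 are both recorded as not active, without a number, so no step can be read between them, and no evidence bears on this result. On these data alone, whether vinyl in place of methyl changes activity in any measurable way stays open.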